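Swapping the Amine Tail on a Kinase-Type Scaffold

The source may report more compounds than this note shows. Statements on the series, on what has been measured and on what is new or still open speak of the compounds shown alone.

Compound 1 `COc1cc2c(Oc3ccc(NC(=O)c4nn(-c5ccccc5)c(=O)cc4C)cc3F)ccnc2cc1OCCCN1CCN(C)CC1`: 270 nM
Compound 2 `COc1cc2c(Oc3ccc(NC(=O)c4nn(-c5ccccc5C)c(=O)cc4C)cc3F)ccnc2cc1OCCCN1CCCC1`: 1400 nM

In a functional assay on HT-29 cells (Homo sapiens) for inhibition, read by MTT assay, with a stated time of 72 h (on this read-out higher numbers stand for weaker inhibition and lower numbers for stronger inhibition), compound 2 gives the highest of the two numbers; its nearest neighbour, compound 1, sits beyond the scatter below it. The two differ in two places, so no single step is shown between them. Compound 3 `COc1cc2c(Oc3ccc(NC(=O)c4nn(-c5ccccc5C)c(=O)cc4C)cc3F)ccnc2cc1OCCCN1CCN(C)CC1` carries the change (4-methylpiperazin-1-yl in place of pyrrolidin-1-yl on a saturated chain carbon, three bonds along the chain from an oxygen on an aromatic ring). The expected step of a 2.3-fold lower number from compound 2 to compound 3 (0.37 log units; beyond the scatter) is toward stronger inhibition, of modest size, because compound 1 with the same tail gives 270 nM. Compound 3 is estimated at 600 nM, within 250 nM to 1500 nM.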

Compound 3, half-maximal inhibitory concentration: 3790 nM
The estimate for compound 3 lay 6.3-fold (0.80 log units) below the measured number; the whole stated range lies below it.
By their numbers in this assay, from the lowest: compound 1; then compound 2; then compound 3.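

In this assay, 4-methylpiperazin-1-yl in place of pyrrolidin-1-yl on a saturated chain carbon, three bonds along the chain from an oxygen on an aromatic ring, gives a 2.7-fold higher number from compound 2 to compound 3 (0.43 log units; beyond the scatter), a modest loss of inhibition. With that tail held fixed, methyl in place of hydrogen on an aromatic carbon gives a 14-fold higher number from compound 1 to compound 3 (1.15 log units; beyond the scatter), a large loss, so this methyl matters more than the tail swap. Nothing available explains either step.

From the compounds shown here alone, whether the methyl costs as much with the pyrrolidin-1-yl tail remains open. So does where a morpholin-4-yl tail, or chlorine in place of that methyl, would stand.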